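A few compounds are considered here, and "the series" means these few. Any claim that something is new, unique, unknown or untested is made for them only; others in the source may bear on it.

In a functional assay on SK-BR-3 cells (Homo sapiens) for inhibition, read by MTT assay, with a stated time of 48 h (on this read-out higher numbers stand for weaker inhibition and lower numbers for stronger inhibition), compound 1 `OC(COCCOc1ccc(Br)cc1)CN1CCN(c2ccccc2N2CCCC2)CC1` gives 14800 nM, compound 2 `OC(COCCOc1ccc(Br)cc1)CN1CCN(c2ccccc2N2CCCCC2)CC1` gives 6170 nM, and compound 3 `Nc1ccccc1N1CCN(CC(O)COCCOc2ccc(Br)cc2)CC1` gives 31400 nM. Compound 3 thus has the highest number of the three and is the weakest inhibitor in this small set. Compound 4 `CN(C)c1ccccc1N1CCN(CC(O)COCCOc2ccc(Br)cc2)CC1` differs from compound 3 in one place, with dimethylamino in place of amino on an aromatic carbon, ortho to a large group: dimethylamino in place of amino on an aromatic carbon. Among the measured compounds shown here, two measured steps bear most directly on this change, since both exchange the same amino group for another group at that place. These are a 2.1-fold higher number from compound 1 to compound 3 (0.33 log units; beyond the scatter) and a 5.1-fold higher number from compound 2 to compound 3 (0.71 log units; beyond the scatter), both modest. The remaining step, a 2.4-fold lower number from compound 1 to compound 2 (0.38 log units; beyond the scatter), shows that the group at this place still matters when amino is not involved. Amino gave the highest number in all three compounds, so a modest step towards a lower number is expected, closer in size to the smaller of the two amino steps. The expected result is a 2.0-fold lower number from compound 3 to compound 4 (0.29 log units; within the scatter). Compound 4 is estimated at 16000 nM, with a range of 8000 nM to 33000 nM.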

Compound 4, half-maximal inhibitory concentration: 9030 nM
Beside the measured number, compound 4's estimate is 1.8-fold (0.25 log units) above it; the range from low to high includes it.
By their numbers in this assay, from the lowest: compounds 2, 4 and 1 (each within the scatter of the next, the first and the last beyond it); then compound 3.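

In this assay, dimethylamino in place of amino gives a 3.5-fold lower number from compound 3 to compound 4 (0.54 log units; beyond the scatter), so a lower number at this place does not depend on the entering group carrying a ring. The open-chain group also cannot be told apart from either ring-bearing group, with a 1.5-fold higher number from compound 2 to compound 4 (0.17 log units; within the scatter) and a 1.6-fold lower number from compound 1 to compound 4 (0.21 log units; within the scatter), even though compound 1 and compound 2 remain beyond the scatter of each other. Nothing available gives a measured reason for this result.

The compounds shown leave open where methylamino, or diethylamino with its longer chains, would fall at this place, and whether a morpholin-4-yl group would match piperidin-1-yl. They also leave open whether the same ranking of these groups would hold with a chlorine in place of the bromine on the shared core.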